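From dimethylamino to pyrrolidin-1-yl on a shared core

A few compounds are considered here, and "the series" means these few. Any claim that something is new, unique, unknown or untested is made for them only; others in the source may bear on it.

Measured in a functional assay on A549 cells (Homo sapiens) for antiproliferative activity, read by MTT assay, with a stated time of 48 h; a higher number here means a weaker inhibitor, a lower number a stronger inhibitor:
Compound 1 `CC(C)=CCC[C@]1(C)/C=C/[C@@H](OC(=O)C=C(C)C)[C@](C)(O)/C=C/C(=O)/C(C(=O)O)=C\C1`: > 10000 nM, a limit of the assay
Compound 2 `CC(C)=CCC[C@]1(C)/C=C/[C@@H](OC(=O)C=C(C)C)[C@](C)(O)/C=C/C(=O)/C(CCl)=C\C1`: 150 nM
Compound 3 `CC(C)=CCC[C@]1(C)/C=C/[C@@H](OC(=O)C=C(C)C)[C@](C)(O)/C=C/C(=O)/C(CN(C)C)=C\C1`: 590 nM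

Compound 3 holds the higher of the two true numbers, and its only numerical neighbour is compound 2, shown by a 3.9-fold higher number from compound 2 to compound 3 (0.59 log units; beyond the scatter). Compound 4 `CC(C)=CCC[C@]1(C)/C=C/[C@@H](OC(=O)C=C(C)C)[C@](C)(O)/C=C/C(=O)/C(CN2CCCC2)=C\C1` differs from compound 3 as follows: pyrrolidin-1-yl in place of dimethylamino on a saturated chain carbon bound to a double-bonded ring carbon. This puts pyrrolidin-1-yl in place of dimethylamino on a saturated chain carbon bound to a double-bonded ring carbon. Within the data shown here, no measured step makes this exchange, but three changed the same place: an at least 66-fold lower number from compound 1 to compound 2 (1.82 log units; beyond the scatter), which is large, an at least 16-fold lower number from compound 1 to compound 3 (1.22 log units; beyond the scatter), also large, and the modest step from chloro to dimethylamino. Since one amine replaces another here, no step beyond the scatter is expected in this assay. The expected change is a 1.2-fold lower number from compound 3 to compound 4 (0.07 log units; within the scatter). The estimate for compound 4 is 500 nM, with an expected range of 200 nM to 1300 nM.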

Compound 4, half-maximal inhibitory concentration: 180 nM
Compound 4: middle estimate off by 2.8-fold (0.44 log units), on the high side, and the stated range ends above it.
By their numbers in this assay, from the lowest: compounds 2 and 4 (each within the scatter of the next); then compound 3. At a limit, above all of these: compound 1.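

In this assay, exchanging one amine for another on the saturated chain carbon still moved the number, with a 3.3-fold lower number from compound 3 to compound 4 (0.52 log units; beyond the scatter), so the result at this place does not follow from having an amine there alone. Compound 4 also sits level with the chloro compound, with a 1.2-fold higher number from compound 2 to compound 4 (0.08 log units; within the scatter), so the gap between chloro and dimethylamino does not extend to every amine shown. The step from carboxy, an at least 55-fold lower number from compound 1 to compound 4 (1.74 log units; beyond the scatter), is only a bound, as it rests on a limit for compound 1: the limit of > 10000 nM in this assay, at which 1 of the 4 values shown sits.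

On these data alone, whether piperidin-1-yl, morpholin-4-yl or a primary amine would fall with pyrrolidin-1-yl or with dimethylamino stays open. So does whether a longer chain between the ring carbon and the nitrogen would keep these numbers.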